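This account rests on a few compounds, and the source may have more. Where it says the series, first, only, none or still open, it means among the compounds named here.

The series rests on a shared core carrying a butyl hydroxyurea and a trimethoxyphenyl-substituted oxolane, and it is read in a functional assay on the whole organism for inhibition, with Mus musculus as the target, at a dose of 3 mg/kg; a higher number here means more inhibition at the dose given (going by the name of the read-out), a lower number less inhibition. Compound 1, `CCCCN(O)C(=O)Nc1cc([C@@H]2CC[C@@H](c3cc(OC)c(OC)c(OC)c3)O2)cc(OC)c1OCCSc1ccc(Br)cc1`, gives 3% in this assay. Compound 2, `CCCCN(O)C(=O)Nc1cc([C@@H]2CC[C@@H](c3cc(OC)c(OC)c(OC)c3)O2)cc(OC)c1OCCS(=O)(=O)c1c(F)c(F)cc(F)c1F`, gives 12% in this assay; its reading and that of compound 1 lie within the scatter of each other, so the two are not separated by the numbers shown. Among the measured compounds shown here, no step between two measured compounds that differ in a single place is available, so the effect of a change at the sulfonyl sulfur has not been measured.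

Compound 3, `CCCCN(O)C(=O)Nc1cc([C@@H]2CC[C@@H](c3cc(OC)c(OC)c(OC)c3)O2)cc(OC)c1OCCS(=O)(=O)c1ccccc1Br`, differs from compound 2 in one place: 2-bromophenyl in place of 2,3,5,6-tetrafluorophenyl on a sulfonyl sulfur. Since both readings stand low and close, the step from compound 2 to compound 3 in this assay is expected to be small and not beyond the scatter, which a number 4 percentage points lower from compound 2 to compound 3 (within the scatter) expresses. For compound 3 the estimate in this assay is 8%, with a range from 0% to 25%.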

Compound 3, a percentage reported as inhibition, in the whole organism at one dose (the size of the read-out at that dose, not a potency): 9%
Compound 3: middle estimate off by 1 percentage points, on the low side; measured number inside the range.
By their numbers in this assay, from the lowest: compounds 1, 3 and 2 (each within the scatter of the next).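

In this assay, a number 3 percentage points lower from compound 2 to compound 3 (within the scatter), so 2-bromophenyl and 2,3,5,6-tetrafluorophenyl on a sulfonyl sulfur are not told apart at this dose. The other step, a number 6 percentage points higher from compound 1 to compound 3 (within the scatter), shows that exchanging (4-bromophenyl)sulfanyl for (2-bromophenyl)sulfonyl on the saturated chain carbon does not separate those two compounds either, so neither change moves the reading beyond the scatter. Nothing available here offers an explanation for these readings.

As far as these compounds go, it remains open whether a group of another kind on the sulfonyl sulfur, such as a methyl group or a pyridine ring, would move the reading beyond the scatter. From the compounds shown here alone, it is equally open whether a carboxylic acid at the end of the saturated chain, in place of the sulfonyl group, would do so.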